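From 4-methylphenyl to (methylamino)methyl on the carbonyl carbon

The compounds below may be only part of what the source reports. "The series", "measured", "known", "first", "only" and "open" are said of these compounds alone.

In a functional assay on HepG2 cells (Homo sapiens) for cytotoxicity, read by MTT assay, with a stated time of 48 h (a lower number here means a stronger inhibitor, a higher number a weaker inhibitor), compound 2 (`Cc1ccc(C(=O)N2N=C(c3cc4ccccc4oc3=O)CC2c2ccccc2)cc1`) reads 52300 nM while compound 1 (`CC(=O)Oc1ccccc1C1CC(C)=NN1C(=O)CN(C(C)C)C(C)C`) reads 34100 nM and the two lie within the scatter of each other. Compound 3 (`CNCC(=O)N1N=C(c2cc3ccccc3oc2=O)CC1c1ccccc1`) differs from compound 2 by (methylamino)methyl in place of 4-methylphenyl on a carbonyl carbon. Within the data shown here, no measured pair covers this change. The expected step in this assay is small and towards a lower number: a 2.1-fold lower number from compound 2 to compound 3 (0.32 log units; beyond the scatter) (estimated). Compound 3 is estimated at 25000 nM (expected range 8000 nM to 70000 nM).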

Compound 3, half-maximal inhibitory concentration: 24000 nM
Compound 3: middle estimate off by 1.0-fold (0.02 log units), on the high side; low and high end bracket the measured number.
By their numbers in this assay, from the lowest: compounds 3, 1 and 2 (each within the scatter of the next, the first and the last beyond it).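

On the carbonyl carbon whose other neighbour is the amide-type nitrogen in a ring, the 4-methylphenyl ring is not needed to keep this level of cytotoxicity: in this assay, replacing it with the ring-free (methylamino)methyl gives a 2.2-fold lower number from compound 2 to compound 3 (0.34 log units; beyond the scatter). Among these compounds, this is the first one-place comparison, and it shows that this position accepts a chain carrying a nitrogen.

As far as these compounds go, whether the nitrogen matters, or only the loss of the ring, stays open; a propyl chain or a dimethylamino group in the same place would separate the two. Nothing available explains the step.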